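Aryl Swap on a Thiosemicarbazone Side Chain

The compounds below may be only part of what the source reports. "The series", "measured", "known", "first", "only" and "open" are said of these compounds alone.

Measured compounds:
compound 1, `CC1=CC[C@@H]([C@@](C)(O)CCCC(C)(C)NC=S)CC1` — in a functional assay on NCI-H460 cells (Homo sapiens) for cytotoxicity, read by sulforhodamine B assay (a lower number here means a stronger inhibitor of growth, a higher number a weaker inhibitor of growth), compound 1 reports only an assay limit, > 100000 nM
compound 2, `CC1=CC[C@@H]([C@@](C)(O)CCCC(C)(C)NC(=S)NN)CC1` — compound 2 gives 84000 nM
compound 3, `CC1=CC[C@@H]([C@@](C)(O)CCCC(C)(C)NC(=S)N/N=C\c2ccc(O)cc2)CC1` — compound 3 gives 20700 nM

Compound 3 holds the lowest of the two numbers; the gap to its nearest neighbour is a 4.1-fold lower number from compound 2 to compound 3 (0.61 log units; beyond the scatter). Compound 4, `CC1=CC[C@@H]([C@@](C)(O)CCCC(C)(C)NC(=S)N/N=C\c2ccccc2Cl)CC1`, carries 2-chlorophenyl in place of 4-hydroxyphenyl on a carbon with a double bond to nitrogen. Within the data shown here, the measured steps, an at least 1.1-fold lower number from compound 1 to compound 2 (0.07 log units; that floor lies within the scatter) and a 4.1-fold lower number from compound 2 to compound 3 (0.61 log units; beyond the scatter), both concern building the side chain rather than exchanging one aryl group for another, so neither bears directly on this change; the second shows only that the aryl group matters. No step beyond the scatter is therefore expected, a 1.4-fold lower number from compound 3 to compound 4 (0.14 log units; within the scatter). Compound 4 is estimated at 15000 nM, within 5000 nM to 50000 nM.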

Compound 4, concentration for total growth inhibition: > 100000 nM
Compound 4: only a limit was reported (the forecaster's own chance of this, stated with the estimate: 5%); at least 6.6-fold (0.82 log units) between middle value and limit.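

On the carbon with a double bond to nitrogen, the aryl group cannot be exchanged freely: in this assay, 2-chlorophenyl in place of 4-hydroxyphenyl gives an at least 4.8-fold higher number from compound 3 to compound 4 (0.68 log units; beyond the scatter). The gain seen with 4-hydroxyphenyl does not carry over to 2-chlorophenyl, which gives an at least 1.1-fold higher number from compound 2 to compound 4 (0.07 log units; that floor lies within the scatter). Compound 4 reports only a limit, and the full size of both steps stays open: the limit of > 100000 nM in this assay, at which 2 of the 4 values shown sit.

The exchange alters the substituent and its place together, and the compounds shown do not separate the two. Going by these compounds, how a plain phenyl or a pyridine ring would read in this assay also stays open.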